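The source may report more compounds than this note shows. Statements on the series, on what has been measured and on what is new or still open speak of the compounds shown alone.

Three compounds built on a shared core have been examined in an ADME assay on HepG2 cells (Homo sapiens) for cytotoxicity, with a stated time of 72 h; on this read-out higher numbers stand for an effect only at larger amounts of compound and lower numbers for an effect already at smaller amounts. Compound 1 `Cc1cc(NC(=O)Nc2ccc([N+](=O)[O-])c(C(F)(F)F)c2)c2ccccc2n1` reaches only a limit of the assay, > 25000 nM. Compound 3 `Cc1cc(NC(=O)Nc2ccccc2C(N)=O)c2ccccc2n1` likewise returns a limit, > 25000 nM. For the measured compounds named here, compound 2 `Cc1cc(NC(=O)Nc2cccc(C(F)(F)F)c2)c2ccccc2n1` is the one member of the set that yields an actual number in this assay, 21000 nM. Going by the values given here, the single measured step, an at least 1.1-fold lower number from compound 1 to compound 2 (0.07 log units; that floor lies within the scatter), runs from a limit to a number and carries little weight, since (the limit of > 25000 nM in this assay, at which 2 of the 3 values shown sit). Compound 4 `Cc1cc(NC(=O)Nc2cccc(OC(F)(F)F)c2)c2ccccc2n1` differs from compound 2 in one place: trifluoromethoxy in place of trifluoromethyl on an aromatic carbon. Among the compounds with values here, no measured step touches this exchange of trifluoromethyl for trifluoromethoxy, and the only step that exists lies within the scatter, so nothing beyond the scatter is expected in this assay. Compound 4 is therefore expected to give 23000 nM, within 12000 nM to 45000 nM. The expected step is a 1.1-fold higher number from compound 2 to compound 4 (0.04 log units; within the scatter), with a fair chance that the assay again reports only a limit rather than a number.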

Compound 4, half-maximal effective concentration: 13000 nM
The estimate for compound 4 lay 1.8-fold (0.25 log units) above the measured number, and the stated range covers the measured number.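

In this assay, the exchange on this aromatic carbon, meta to a large group, gives a step between two actual numbers, a 1.6-fold lower number from compound 2 to compound 4 (0.21 log units; within the scatter). That step lies within the scatter, so inserting the oxygen of trifluoromethoxy at this position makes no difference that the assay can separate from repeat variation. Compound 1 could offer no such direct reading, because its value is a limit: the limit of > 25000 nM in this assay, at which 2 of the 4 values shown sit.

The compounds shown leave open whether a different group at this position, such as an amine, a carboxylic acid or a longer alkoxy chain, would shift the number beyond the scatter. They also leave open how trifluoromethoxy would read in a compound that also carries the nitro group of compound 1.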